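Carboxy in Place of Hydroxymethyl: an Expectation for Compound 4

This account rests on a few compounds, and the source may have more. Where it says the series, first, only, none or still open, it means among the compounds named here.

Measured compounds:
compound 1, `O=C(CCCCCc1ccc(Cl)cc1)N1CCOC1=O`, 4600 nM
compound 2, `COc1ccc(CCCCCC(=O)N2CCOC2=O)cc1`, > 20000 nM
compound 3, `O=C(CCCCCc1ccc(CO)cc1)N1CCOC1=O`, 190 nM

In an assay on HEK293 cells for inhibition of N-acylethanolamine-hydrolyzing acid amidase (Rattus norvegicus), read by LC-MS, with a stated time of 30 min (on this read-out higher numbers stand for weaker inhibition and lower numbers for stronger inhibition), compound 3 gives 190 nM, the lowest of the two numbers shown. Its nearest neighbour is compound 1, and the step of a 24-fold lower number from compound 1 to compound 3 (1.38 log units; beyond the scatter) was large. For compound 2 the value > 20000 nM is a limit of the assay, not a number (the limit of > 20000 nM in this assay, at which 1 of the 3 values shown sits). Compound 4, `O=C(O)c1ccc(CCCCCC(=O)N2CCOC2=O)cc1`, differs from compound 3 by carboxy in place of hydroxymethyl on an aromatic carbon. Going by the values given here, no measured step involves a carboxy group, but the two steps at this position, a 24-fold lower number from compound 1 to compound 3 (1.38 log units; beyond the scatter) and an at least 100-fold lower number from compound 2 to compound 3 (2.02 log units; beyond the scatter), show that the group on this aromatic carbon moves the number strongly, and the hydroxymethyl group stands alone at the low end. A rise beyond the scatter is therefore expected for compound 4, about an 11-fold higher number from compound 3 to compound 4 (1.02 log units; beyond the scatter). Compound 4 is estimated at 2000 nM, within 400 nM to 12000 nM.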

Compound 4, half-maximal inhibitory concentration: > 20000 nM
Compound 4 ended at the assay's limit (the forecaster's own chance of this, stated with the estimate: 15%); middle value at least 10-fold (1.00 log units) away from the limit.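

Carboxy in place of hydroxymethyl gives an at least 100-fold higher number from compound 3 to compound 4 (2.02 log units; beyond the scatter), so holding the count at one hydrogen-bond donor and one hydrogen-bond acceptor does not preserve the low number of compound 3. Carboxy also compares poorly with chloro, with an at least 4.3-fold higher number from compound 1 to compound 4 (0.63 log units; beyond the scatter). Compound 4 stands at a limit of the assay, shared with compound 2, so the step between them cannot be read: the limit of > 20000 nM in this assay, at which 2 of the 4 values shown sit.

The compounds shown leave open whether an aminomethyl group or a longer hydroxyalkyl chain on this aromatic carbon would keep the low number of compound 3.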